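The source may hold more compounds than are shown below. What is called first, only, known or untested is meant among the compounds shown, and "the series" means these compounds.

The three measured compounds share one core and differ only in the group on a saturated ring carbon: compound 1 `Cc1cc(O)c(C2=NN(c3ccc(S(N)(=O)=O)cc3)C(c3ccccc3Cl)C2)cc1Cl`, compound 2 `Cc1cc(O)c(C2=NN(c3ccc(S(N)(=O)=O)cc3)C(/C=C/c3ccccc3)C2)cc1Cl` and compound 3 `COc1ccc(C2CC(c3cc(Cl)c(C)cc3O)=NN2c2ccc(S(N)(=O)=O)cc2)cc1OC`. In a functional assay on OVCAR-8 cells (Homo sapiens) for antiproliferative activity, with a stated time of 48 h (a higher number here means a weaker inhibitor of growth, a lower number a stronger inhibitor of growth), compound 1 gives 2940 nM, compound 2 gives 3030 nM and compound 3 gives 3390 nM. Compound 3 stands close to both others, since a 1.2-fold higher number from compound 1 to compound 3 (0.06 log units; within the scatter) and a 1.1-fold higher number from compound 2 to compound 3 (0.05 log units; within the scatter). Compound 4 `COc1ccc(C2CC(c3cc(Cl)c(C)cc3O)=NN2c2ccc(S(N)(=O)=O)cc2)c(OC)c1OC` carries methoxy in place of hydrogen on an aromatic carbon. For the measured compounds named here, the steps that bear on this change are the exchanges at the same carbon, a 1.0-fold higher number from compound 1 to compound 2 (0.01 log units; within the scatter), a 1.2-fold higher number from compound 1 to compound 3 (0.06 log units; within the scatter) and a 1.1-fold higher number from compound 2 to compound 3 (0.05 log units; within the scatter), all within the scatter, so no step beyond the scatter is expected in this assay. Compound 4 is expected to give 3400 nM, between 1700 nM and 6800 nM, an expected 1.0-fold higher number from compound 3 to compound 4 (0.00 log units; within the scatter).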

Compound 4, concentration for 50% growth inhibition: 3920 nM
Compound 4: middle estimate off by 1.2-fold (0.06 log units), on the low side, and the stated range covers the measured number.
By their numbers in this assay, from the lowest: compounds 1, 2, 3 and 4 (each within the scatter of the next).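

In this assay methoxy in place of hydrogen on an aromatic carbon, ortho to a large group and to a methoxy group, gives a 1.2-fold higher number from compound 3 to compound 4 (0.06 log units; within the scatter) so a further methoxy at this place on the ring produces no step beyond the scatter. With a 1.3-fold higher number from compound 2 to compound 4 (0.11 log units; within the scatter) and a 1.3-fold higher number from compound 1 to compound 4 (0.12 log units; within the scatter) the 2,3,4-trimethoxyphenyl group also stays within the scatter of the two other groups on the saturated ring carbon.

From the compounds shown here alone, whether an amine or a carboxylic acid at this aromatic carbon, or a longer chain in place of methoxy, would give a step beyond the scatter stays open. No supporting measurement accounts for these small steps.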